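Swapping Acetyl for Chloro on the Amide Aryl Group

This account rests on a few compounds, and the source may have more. Where it says the series, first, only, none or still open, it means among the compounds named here.

Measured compounds:
compound 1 `O=C(/C=C/C(=O)N1C/C(=C\c2ccc([N+](=O)[O-])cc2)C(=O)/C(=C/c2ccc([N+](=O)[O-])cc2)C1)Nc1ccc(Cl)c(Cl)c1` gives 1700 nM
compound 2 `CC(=O)c1ccc(NC(=O)/C=C/C(=O)N2C/C(=C\c3ccc([N+](=O)[O-])cc3)C(=O)/C(=C/c3ccc([N+](=O)[O-])cc3)C2)cc1` gives 1400 nM
compound 3 `CC(=O)c1ccc(NC(=O)/C=C/C(=O)N2C/C(=C\c3ccccc3)C(=O)/C(=C/c3ccccc3)C2)cc1` gives 5500 nM

These three compounds were tested in a functional assay on L1210 cells (Mus musculus) for cytotoxicity; a lower number here means a stronger inhibitor, a higher number a weaker inhibitor. Compound 3 stands at the highest number of the three, the weakest position in this assay. Its nearest neighbour is compound 1, and compound 2 lies furthest from it; both gaps are beyond the usual scatter, so compound 3 is a genuinely weaker inhibitor than either.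

Compound 4 `O=C(/C=C/C(=O)N1C/C(=C\c2ccccc2)C(=O)/C(=C/c2ccccc2)C1)Nc1ccc(Cl)cc1` has not yet been measured. It differs from compound 3 in one place: chloro in place of acetyl on an aromatic carbon. Going by the values given here, the one measured step that bears on this is the exchange of the aryl group on the amide nitrogen, a 1.2-fold lower number from compound 1 to compound 2 (0.08 log units; within the scatter), which stayed within the scatter. A change of the same kind at the same position is therefore expected to move the number little, and no step beyond the scatter is expected: a 1.1-fold lower number from compound 3 to compound 4 (0.04 log units; within the scatter). Compound 4 is estimated at 5000 nM, with a range from 2500 nM to 11000 nM.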

Compound 4, half-maximal inhibitory concentration: 7800 nM
Estimate against measurement, compound 4: 1.6-fold (0.19 log units) below, within the range that was stated.
By their numbers in this assay, from the lowest: compounds 2 and 1 (each within the scatter of the next); then compounds 3 and 4 (each within the scatter of the next).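

In this assay, the exchange of acetyl for chloro at this position gives a 1.4-fold higher number from compound 3 to compound 4 (0.15 log units; within the scatter), so the aryl group on the amide nitrogen again tolerates a change without a shift beyond the scatter, now on the core of compound 3, which lacks the nitro groups of compound 1 and compound 2. This exchange removes three heavy atoms, including the one hydrogen-bond acceptor of the acetyl, and puts a single chlorine in their place, so in this pair that carbonyl oxygen is not needed to hold the number. Nothing shown here explains why the exchange matters so little.

As far as these compounds go, whether an amine or a carboxylic acid at this position would also leave the number in place remains open. So does whether 4-chlorophenyl would behave the same way on the core of compound 2.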